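A few compounds are considered here, and "the series" means these few. Any claim that something is new, unique, unknown or untested is made for them only; others in the source may bear on it.

Of the compounds shown here, three have been measured in a functional assay on PC-3 cells (Homo sapiens) for antiproliferative activity, read by MTT assay, tested at 5 uM; a lower number here means a weaker effect, a higher number a stronger effect of the compound at the concentration tested. Compound 1 `COc1cc(C(=O)N/N=C/c2ccc(F)c(F)c2)cc(OC)c1OC` gives 43.7% in this assay, and compound 2 `COc1cc(C(=O)N/N=C/c2ccccc2C(F)(F)F)cc(OC)c1OC` gives 52.9%. Compound 3 `COc1ccc(C2OC(c3cc(OC)c(OC)c(OC)c3)=NN2C(C)=O)c(OC)c1` gives 92%, the highest of the three numbers: it stands beyond the scatter above compound 2, the nearest of the other two, and further still above compound 1.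

Compound 4 `COc1cc(C2=NN(C(C)=O)C(c3ccc(F)c(F)c3)O2)cc(OC)c1OC` has not yet been measured. It differs from compound 3 in one place: 3,4-difluorophenyl in place of 2,4-dimethoxyphenyl on a saturated ring carbon. The 3,4-difluorophenyl that enters also appears in compound 1, while the five-membered non-aromatic ring with its acetyl group is kept from compound 3. Going by the values given here, no measured pair shows this particular exchange, so the size of the step is open. Since the starting point is compound 3 at 92%, and compound 1 with the same 3,4-difluorophenyl sits at 43.7%, a drop beyond the scatter seems more likely than a rise, though a number close to compound 3 cannot be ruled out. Compound 4 is therefore expected to give 65% in this assay, within a range from 35% to 90%. The estimated step from compound 3 to compound 4 is a number 27 percentage points lower from compound 3 to compound 4 (beyond the scatter), downward.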

Compound 4, a percentage reported as inhibition, at one concentration (the size of the read-out at that concentration, not a potency): 46.9%
For compound 4 the middle estimate is 18.1 percentage points above the measured one; the range from low to high includes it.
By their numbers in this assay, from the lowest: compounds 1, 4 and 2 (each within the scatter of the next); then compound 3.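

In this assay, putting 3,4-difluorophenyl in place of 2,4-dimethoxyphenyl on the saturated ring carbon gives a number 45.1 percentage points lower from compound 3 to compound 4 (beyond the scatter), a large step. Going by these compounds alone, this is the first direct reading at this place, since the earlier compounds offered no pair that differed in only one spot: with the acetyl group and the rest of the molecule held fixed, the group on this ring carbon alone changes the read-out substantially at the concentration tested. Nothing measured here explains why the step is so large, and a single exchange cannot show whether the loss follows from the two methoxy groups leaving or the two fluorines entering.

A plain phenyl group, or a phenyl carrying a single methoxy group, on the same ring carbon would help separate those two possibilities. Going by these compounds, it also remains open whether a different kind of group here, such as an amine-bearing ring like pyridine or a longer alkyl chain, would keep the read-out near that of compound 3 or lower it further.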